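Sulfonamide series: step from compound 2 to compound 3

A few compounds are considered here, and "the series" means these few. Any claim that something is new, unique, unknown or untested is made for them only; others in the source may bear on it.

Compound 1 `O=S(=O)(NCCCNCc1ccccc1Cl)c1cc(C(F)(F)F)cc(C(F)(F)F)c1` and compound 2 `O=S(=O)(NCCCNCc1ccc(Cl)c(Cl)c1)c1cc(C(F)(F)F)cc(C(F)(F)F)c1` have been measured in a functional assay on MIA PaCa-2 cells (Homo sapiens) for inhibition, read by MTT assay, with a stated time of 72 h; a lower number here means a stronger inhibitor of growth, a higher number a weaker inhibitor of growth. Compound 1 gives 11000 nM; compound 2 gives 2700 nM, the lowest of the two numbers, with the step of a 4.1-fold lower number from compound 1 to compound 2 (0.61 log units; beyond the scatter) lying beyond the scatter. Compound 3 `CN(CCCNS(=O)(=O)c1cc(C(F)(F)F)cc(C(F)(F)F)c1)Cc1ccccc1` carries benzyl(methyl)amino in place of (3,4-dichlorobenzyl)amino on a saturated chain carbon, three bonds along the chain from a sulfonamide nitrogen. Going by the values given here, the one measured step concerns only the chlorine pattern on the benzyl ring; the change to compound 3 removes both chlorines and also replaces the amine hydrogen with a methyl, for which no step is known. Partial reversal of the gain seen in a 4.1-fold lower number from compound 1 to compound 2 (0.61 log units; beyond the scatter) is expected, so a modestly higher number, estimated as a 3.0-fold higher number from compound 2 to compound 3 (0.47 log units; beyond the scatter). Compound 3 is expected to give 8000 nM, within a range of 2500 nM to 25000 nM.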

Compound 3, concentration for 50% growth inhibition: 33000 nM
Compound 3: middle estimate off by 4.1-fold (0.62 log units), on the low side; the measured number lies above the stated range.
By their numbers in this assay, from the lowest: compound 2; then compound 1; then compound 3.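

In this assay, benzyl(methyl)amino on a saturated chain carbon, three bonds along the chain from a sulfonamide nitrogen, gives the highest number of the series, with a 12-fold higher number from compound 2 to compound 3 (1.09 log units; beyond the scatter) and a 3.0-fold higher number from compound 1 to compound 3 (0.48 log units; beyond the scatter). This end of the molecule therefore moves the number in both directions, and the loss here exceeds the gain seen between the two chlorine patterns. Nothing at hand explains the loss.

The change removes the chlorines and adds the methyl together, leaving the share of each unresolved. Benzylamino or 3,4-dichlorobenzyl(methyl)amino would separate the two.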